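Notes on compound 4 in the shared-core series

The source may report more compounds than this note shows. Statements on the series, on what has been measured and on what is new or still open speak of the compounds shown alone.

Compound 1 `O=c1cc(/C=N\c2ccccc2O)c2c(OCc3ccccc3)cc(OCc3ccccc3)cc2o1`: in a functional assay, read by spectrophotometry, with a stated time of 5 min (a lower number here means a stronger inhibitor, a higher number a weaker inhibitor), compound 1 gives 33100 nM.
Compound 3 `O=c1cc(/C=N\c2ccc(O)cc2)c2c(OCc3ccccc3)cc(OCc3ccccc3)cc2o1`: in this assay compound 3 gives 249000 nM.
Compound 2 `O=c1cc(/C=N\Nc2ccc([N+](=O)[O-])cc2)c2ccc(OCc3ccccc3)cc2o1`: in this assay compound 2 gives > 2000000 nM, which is a limit of the assay and not a number.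

Compound 3 stands highest of the two numbers in this assay; the nearest is compound 1, and the step of a 7.5-fold higher number from compound 1 to compound 3 (0.88 log units; beyond the scatter) is beyond the scatter. Compound 4 `O=c1cc(/C=N\Nc2ccc([N+](=O)[O-])cc2)c2c(OCc3ccccc3)cc(OCc3ccccc3)cc2o1` differs from compound 3 in one place: (4-nitrophenyl)amino in place of 4-hydroxyphenyl on a double-bonded nitrogen. Going by the values given here, no measured step covers this exchange on the same core. Compound 2 carries the same (4-nitrophenyl)amino group on a core with one benzyloxy group, and for compound 2 only the limit of > 2000000 nM in this assay, at which 1 of the 3 values shown sits, is recorded. Compound 4 is therefore expected to show the step of a 6.0-fold higher number from compound 3 to compound 4 (0.78 log units; beyond the scatter) in this assay, upward and large, with a limit the most likely outcome. Compound 4 is estimated at 1500000 nM, range 300000 nM to 6000000 nM.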

Compound 4, half-maximal inhibitory concentration: 419000 nM
Estimate against measurement, compound 4: 3.6-fold (0.55 log units) above; low and high end bracket the measured number.
By their numbers in this assay, from the lowest: compound 1; then compounds 3 and 4 (each within the scatter of the next). At a limit, above all of these: compound 2.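

In this assay, (4-nitrophenyl)amino on the double-bonded nitrogen cannot be told apart from 4-hydroxyphenyl on the shared core: a 1.7-fold higher number from compound 3 to compound 4 (0.23 log units; within the scatter). Against 2-hydroxyphenyl the same group gives a 13-fold higher number from compound 1 to compound 4 (1.10 log units; beyond the scatter), so 2-hydroxyphenyl alone stands apart among the three groups at this place on this core. Benzyloxy in place of hydrogen on an aromatic carbon gives an at least 4.7-fold lower number from compound 2 to compound 4 (0.67 log units; beyond the scatter), a step that rests on a limit and not a number: the limit of > 2000000 nM in this assay, at which 1 of the 4 values shown sits.

Still open, as far as these compounds go, is how an amine or a short alkyl chain would read at this place. Also open, from the compounds shown here alone, is whether a methoxy group in place of the hydroxyl of 2-hydroxyphenyl would hold the number of compound 1.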